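The compounds below may be only part of what the source reports. "The series", "measured", "known", "first", "only" and "open" are said of these compounds alone.

Measured so far:
compound 1 `O=C(Nc1cc(F)cc(F)c1)c1ccc2cccnc2c1O` at 3340 nM
compound 2 `O=C(Nc1ccc(C(F)(F)F)cc1)c1cc(Br)c(F)cc1O` at 820 nM

In a functional assay on KG-1 cells (Homo sapiens) for cytotoxicity, read by luminescence and CellTiter-Glo, with a stated time of 3 days (on this read-out higher numbers stand for weaker inhibition and lower numbers for stronger inhibition), compound 2 holds the lower of these two numbers, and its gap to compound 1 lies beyond the usual scatter. These two compounds differ in more than one place, so they offer no measured single change to reason from. Compound 3 `O=C(Nc1ccc(C(F)(F)F)cc1)c1cc(Br)c(-c2ccccc2)cc1O` keeps the rest of compound 2 but carries phenyl in place of fluoro on an aromatic carbon, ortho to a bromo group. Going by the values given here, with no measured precedent for this swap, no step beyond the scatter is expected in this assay and no direction can be favoured with confidence. The estimated change is a 1.2-fold lower number from compound 2 to compound 3 (0.07 log units; within the scatter) and a wide margin around it is expected. Compound 3 is estimated at 700 nM within an expected range of 200 nM to 2500 nM on this read-out.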

Compound 3, half-maximal inhibitory concentration: 400 nM
Compound 3: middle estimate off by 1.8-fold (0.24 log units), on the high side; measured number inside the range.
By their numbers in this assay, from the lowest: compound 3; then compound 2; then compound 1.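

In this assay, going by these compounds alone, compound 3 gives the first measured single change, at the place ortho to a bromo group: phenyl in place of fluoro gives a 2.1-fold lower number from compound 2 to compound 3 (0.31 log units; beyond the scatter). The step is modest but beyond the scatter, and it shows that a single fluorine at this place can give way to a six-membered aromatic ring of carbon only with a lower number, not a higher one. Nothing measured here explains the drop. On these data alone, whether a pyridine ring, an amine or a carboxylic acid at this place would move the number in the same direction remains open. As far as these compounds go, it is also open whether the phenyl itself matters or whether a smaller or non-aromatic group, such as methyl or cyclohexyl, would give a similar step.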